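Amide chain length in a stilbene cinnamamide series

The compounds below may be only part of what the source reports. "The series", "measured", "known", "first", "only" and "open" are said of these compounds alone.

Working notes. Compound 1 `CCNC(=O)/C=C/c1c(/C=C/c2ccc(OC)cc2)cc(OC)cc1OC` carries an ethyl group on the amide nitrogen; in a functional assay on A549 cells (Homo sapiens) for inhibition, read by MTT assay, with a stated time of 48 h (on this read-out lower numbers stand for stronger inhibition and higher numbers for weaker inhibition), compound 1 gives 7860 nM. Compound 2 `CCCCCCCCNC(=O)/C=C/c1c(/C=C/c2ccc(OC)cc2)cc(OC)cc1OC` carries an octyl group there, and in this assay compound 2 gives 8660 nM. Compound 3 `CCC(C)NC(=O)/C=C/c1c(/C=C/c2ccc(OC)cc2)cc(OC)cc1OC` carries a sec-butyl group, and in this assay compound 3 gives 3950 nM. Compound 2 gives the largest of the three numbers, but the step of a 1.1-fold higher number from compound 1 to compound 2 (0.04 log units; within the scatter) is within the scatter, while the step of a 2.2-fold lower number from compound 2 to compound 3 (0.34 log units; beyond the scatter) is beyond it, and the step of a 2.0-fold lower number from compound 1 to compound 3 (0.30 log units; within the scatter) falls at the edge of the scatter.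

Compound 4 `COc1ccc(/C=C/c2cc(OC)cc(OC)c2/C=C/C(=O)NC(C)C)cc1` is the next member. The change from compound 2 is isopropyl in place of octyl on an amide-type nitrogen. The step that bears directly on it is a 2.2-fold lower number from compound 2 to compound 3 (0.34 log units; beyond the scatter), a branched short group replacing the octyl group; the step of a 2.0-fold lower number from compound 1 to compound 3 (0.30 log units; within the scatter) points the same way, while a 1.1-fold higher number from compound 1 to compound 2 (0.04 log units; within the scatter) shows that chain length alone moved little. Isopropyl is a branched short group of the same kind as sec-butyl, so in this assay compound 4 is expected to sit near compound 3, with a modest lowering of the number expected for the step of a 1.9-fold lower number from compound 2 to compound 4 (0.28 log units; within the scatter). The estimate for compound 4 is 4500 nM, within the range 2000 nM to 9500 nM, on the strength of a 2.2-fold lower number from compound 2 to compound 3 (0.34 log units; beyond the scatter).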

Compound 4, half-maximal inhibitory concentration: 2360 nM
For compound 4 the middle estimate is 1.9-fold (0.28 log units) above the measured one; low and high end bracket the measured number.
By their numbers in this assay, from the lowest: compounds 4, 3, 1 and 2 (each within the scatter of the next, the first and the last beyond it).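

In this assay, a 3.7-fold lower number from compound 2 to compound 4 (0.56 log units; beyond the scatter) and a 3.3-fold lower number from compound 1 to compound 4 (0.52 log units; beyond the scatter) are both beyond the scatter, so on the amide-type nitrogen isopropyl stands clear of both the octyl and the ethyl group, whereas sec-butyl stood clear of octyl alone. Against this, a 1.7-fold lower number from compound 3 to compound 4 (0.22 log units; within the scatter) is within the scatter, so the two branched groups cannot be told apart; the reading that branched groups give lower numbers than unbranched ones holds firmly for compound 4 against compound 1 and compound 2 and for compound 3 against compound 2, while compound 3 against compound 1 goes against it, with a 2.0-fold lower number from compound 1 to compound 3 (0.30 log units; within the scatter) within the scatter. No supporting data bear on why the isopropyl group gives this result.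

The compounds shown leave open how a tert-butyl group, a cyclohexyl ring or a chain ending in an amine or a carboxylic acid would read on the same nitrogen. They also leave open whether replacing the amide hydrogen with a methyl group would keep the number of compound 4 at 2360 nM.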